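A Hydroxy-Methoxyphenyl Variant in a Hydrazone Urea Series

The source may report more compounds than this note shows. Statements on the series, on what has been measured and on what is new or still open speak of the compounds shown alone.

Among the compounds with values here, compound 3 `COc1ccc(/C=N/NC(=O)Nc2ccc(Oc3ccnc(-c4nncn4CCN(C)C)c3)c(F)c2)c(OC)c1` gives 12600 nM in a functional assay on U-87MG ATCC cells (Homo sapiens) for cytotoxicity, read by MTT assay, with a stated time of 72 h (on this read-out higher numbers stand for weaker inhibition and lower numbers for stronger inhibition), the highest of the three numbers measured so far. Compound 1 `COc1ccc(OC)c(/C=N/NC(=O)Nc2ccc(Oc3ccnc(-c4nncn4CCN(C)C)c3)c(F)c2)c1` gives 6400 nM in this assay, and compound 2 `CN(C)CCn1cnnc1-c1cc(Oc2ccc(NC(=O)N/N=C/c3c(O)ccc4ccccc34)cc2F)ccn1` gives 620 nM. The step of a 2.0-fold higher number from compound 1 to compound 3 (0.29 log units; within the scatter) shows that exchanging one dimethoxyphenyl arrangement for the other changes little, whereas a 10-fold lower number from compound 1 to compound 2 (1.01 log units; beyond the scatter) and a 20-fold higher number from compound 2 to compound 3 (1.31 log units; beyond the scatter) show that the 2-hydroxynaphthalen-1-yl group brings a large lowering of the number. Compound 4 `COc1cc(/C=N/NC(=O)Nc2ccc(Oc3ccnc(-c4nncn4CCN(C)C)c3)c(F)c2)ccc1O` differs from compound 3 in one place: 4-hydroxy-3-methoxyphenyl in place of 2,4-dimethoxyphenyl on a carbon with a double bond to nitrogen. The entering group contributes a hydrogen-bond donor, as the group in compound 2 does, yet it remains a single six-membered aromatic ring bearing methoxy, as in compounds 1 and 3. The two measured steps that bear on this change thus pull in different directions, and only a moderate movement is expected. Compound 4 is expected to give a lower number than compound 3 in this assay, by a 3.2-fold lower number from compound 3 to compound 4 (0.50 log units; beyond the scatter), with an estimate of 4000 nM and a range from 1500 nM to 12000 nM.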

Compound 4, half-maximal inhibitory concentration: > 100000 nM
Compound 4: no number, only a limit; the forecaster's own chance of this, stated with the estimate: 5%; at least 25-fold (1.39 log units) between middle value and limit.
By their numbers in this assay, from the lowest: compound 2; then compounds 1 and 3 (each within the scatter of the next). At a limit, above all of these: compound 4.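

Compound 4 gives no number in this assay, only a limit: the limit of > 100000 nM in this assay, at which 1 of the 4 values shown sits. The two dimethoxyphenyl groups had stayed within the scatter of each other, yet 4-hydroxy-3-methoxyphenyl at this place brings an at least 7.9-fold higher number from compound 3 to compound 4 (0.89 log units; beyond the scatter) and an at least 15-fold higher number from compound 1 to compound 4 (1.19 log units; beyond the scatter), which shows that this position does respond to a change on a single six-membered aromatic ring. Carrying a hydrogen-bond donor does not alone go with a lower number here: 2-hydroxynaphthalen-1-yl and 4-hydroxy-3-methoxyphenyl both carry one, and the exchange between them gives an at least 160-fold higher number from compound 2 to compound 4 (2.20 log units; beyond the scatter).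

The compounds shown leave open whether the hydroxy group or the placing of the methoxy group goes with this rise, and whether the naphthalene part or its hydroxy group goes with the low number of compound 2. They also leave open what an amine or a carboxylic acid on the aromatic ring would give at this place.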